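The compounds below may be only part of what the source reports. "The series", "measured", "known", "first", "only" and "open" are said of these compounds alone.

Of the compounds shown here, two built on one shared core have been measured in a functional assay on CHO cells for positive allosteric modulation of metabotropic glutamate receptor 2 (Homo sapiens), read by scintillation counting and GTPgammaS binding, with a stated time of 30 min; a higher number here means that more compound is needed for the effect, a lower number that less compound is needed. Compound 1 `CC(C)CCn1ccc(-c2ccccc2)c(C#N)c1=O` gives 8510 nM in this assay. Compound 2 `Cc1ncccc1Oc1ccc(-c2ccn(CCC(C)C)c(=O)c2C#N)cc1` gives 275 nM in this assay. Within the data shown here, the single step between them, a 31-fold lower number from compound 1 to compound 2 (1.49 log units; beyond the scatter), is large, and it leaves compound 2 with the lowest of the two numbers, its only neighbour being compound 1 at a number higher by that same margin.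

Compound 3 `Cc1ccc(Oc2ccc(-c3ccn(CCC(C)C)c(=O)c3C#N)cc2)c(C)n1` has not yet been measured. It differs from compound 2 in one place: methyl in place of hydrogen on an aromatic carbon. Among the measured compounds shown here, no measured step bears on this change. For the measured compounds named here, the only step in hand concerns a different group at a different place, so it offers no guide to the size or direction of the present change. Going by the values given here, with no precedent of this kind, the change expected in this assay is small, with no direction favoured beyond the scatter.

Compound 3 is therefore estimated to give 250 nM in this assay, with a range from 80 nM to 800 nM. The expected step is a 1.1-fold lower number from compound 2 to compound 3 (0.04 log units; within the scatter).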

Compound 3, half-maximal effective concentration: 100 nM
The estimate for compound 3 lay 2.5-fold (0.40 log units) above the measured number; measured number inside the range.
By their numbers in this assay, from the lowest: compound 3; then compound 2; then compound 1.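

In this assay, a single methyl on an aromatic carbon next to the ring nitrogen turns the (2-methylpyridin-3-yl)oxy group into the (2,6-dimethylpyridin-3-yl)oxy group and gives a 2.8-fold lower number from compound 2 to compound 3 (0.44 log units; beyond the scatter). This shows that the number still responds to a change on this outer ring, and that a methyl at this place, meta to the existing methyl group, is tolerated and takes the number lower. Measured against the unsubstituted aromatic carbon of compound 1, the (2,6-dimethylpyridin-3-yl)oxy group now accounts for an 85-fold lower number from compound 1 to compound 3 (1.93 log units; beyond the scatter), although nothing available explains why the added methyl has this effect.

The compounds shown leave open whether the effect is particular to a methyl, since an ethyl, a methoxy, a chlorine or an amine at the same place could move the number further or reverse the step. They also leave open how much depends on the methyl already on the ring, which a (6-methylpyridin-3-yl)oxy group would separate from the new one.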